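The source may report more compounds than this note shows. Statements on the series, on what has been measured and on what is new or still open speak of the compounds shown alone.

Compound 2, `COc1ccc(C(=O)/C=C/c2cc(-c3cc(OC)c(OC)c(OC)c3)n[nH]2)cc1OC`, is measured in a functional assay on M14 cells (Homo sapiens) for inhibition, read by sulforhodamine B assay, with a stated time of 48 h (on this read-out lower numbers stand for stronger inhibition of growth and higher numbers for weaker inhibition of growth), and gives 3690 nM. Compound 1, `COc1cc(-c2cc(/C=C/C(=O)c3ccc(Cl)c(Cl)c3)[nH]n2)cc(OC)c1OC`, reaches only > 100000 nM in this assay, a limit of the measurement rather than a number. For the measured compounds named here, compound 2 therefore stands as the only numbered value here, the other being a limit (the limit of > 100000 nM in this assay, at which 1 of the 2 values shown sits). Going by the values given here, the change between them is an at least 27-fold lower number from compound 1 to compound 2 (1.43 log units; beyond the scatter), the one measured step.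

Compound 3, `COc1ccc(C(=O)/C=C/c2cc(-c3cc(OC)c(OC)c(OC)c3)n[nH]2)cc1`, differs from compound 2 by hydrogen in place of methoxy on an aromatic carbon. Among the compounds with values here, the only measured step concerns a different change, the swap of the whole substituted phenyl on the carbonyl carbon, so it bears on this step only loosely; it shows that this part of the structure can move the number strongly. Removing one methoxy is a smaller change, so a modest step is expected for compound 3, a 1.9-fold higher number from compound 2 to compound 3 (0.28 log units; within the scatter), toward a somewhat higher number. Compound 3 is estimated at 7000 nM, within 2000 nM to 25000 nM.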

Compound 3, concentration for total growth inhibition: 4930 nM
For compound 3 the middle estimate is 1.4-fold (0.15 log units) above the measured one; measured number inside the range.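

Going from 3,4-dimethoxyphenyl to 4-methoxyphenyl gives a 1.3-fold higher number from compound 2 to compound 3 (0.13 log units; within the scatter), so in this assay the loss of this methoxy cannot be told apart from repeat-measurement noise. The large difference from the dichlorinated compound therefore remains with one methoxy on this phenyl ring, as the change to 4-methoxyphenyl gives an at least 20-fold lower number from compound 1 to compound 3 (1.30 log units; beyond the scatter). Compound 1 stands at a limit and not at a number, so this step gives only a minimum size: the limit of > 100000 nM in this assay, at which 1 of the 3 values shown sits.

The compounds shown leave open whether the remaining methoxy matters, since a phenyl ring carrying no substituent would be needed to test that. They also leave open whether another group in its place, such as an amine or a carboxylic acid, would keep the number near that of compound 3.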